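The source may hold more compounds than are shown below. What is called first, only, known or untested is meant among the compounds shown, and "the series" means these compounds.

Compound 2 `Cc1ccc(-n2cc(-c3cccc(NS(=O)(=O)c4c[nH]c(=O)[nH]c4=O)c3)nn2)cc1` and compound 1 `O=c1[nH]cc(S(=O)(=O)Nc2ccccc2-c2cn(-c3ccc(Cl)cc3)nn2)c(=O)[nH]1` share a core and were both tested in a functional assay on SGC-7901 cells (Homo sapiens) for antiproliferative activity, read by MTT assay, with a stated time of 24 h; on this read-out higher numbers stand for weaker inhibition and lower numbers for stronger inhibition. In that assay compound 2 gives 9430 nM, the highest of the two numbers available, while compound 1 gives 2700 nM, a lower number by a margin beyond the scatter. Compound 3 `O=c1[nH]cc(S(=O)(=O)Nc2cccc(-c3cn(-c4ccc(Cl)cc4)nn3)c2)c(=O)[nH]1` has not yet been measured. It differs from compound 2 in one place: chloro in place of methyl on an aromatic carbon, which, read one bond further out, is 4-methylphenyl to 4-chlorophenyl, on an aromatic carbon of a six-membered aromatic ring of carbon only, para to a large group. Within the data shown here, no measured pair in this set shows this change on its own, so nothing here fixes its size. The expectation is a step from compound 2 to compound 3 of a 1.6-fold lower number from compound 2 to compound 3 (0.20 log units; within the scatter), toward a somewhat lower number but not clearly beyond the scatter. Compound 3 is therefore estimated at 6000 nM in this assay, within a range from 2500 nM to 15000 nM.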

Compound 3, half-maximal inhibitory concentration: 2160 nM
For compound 3 the middle estimate is 2.8-fold (0.44 log units) above the measured one; the whole stated range lies above it.
By their numbers in this assay, from the lowest: compounds 3 and 1 (each within the scatter of the next); then compound 2.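

In this assay, among these compounds, this is the first pair in the set that differs in one place, and it shows that this position is sensitive to the substituent: chloro in place of methyl, on an aromatic carbon para to a large group, gives a 4.4-fold lower number from compound 2 to compound 3 (0.64 log units; beyond the scatter), a modest step but one beyond the scatter. With 4-chlorophenyl in place of 4-methylphenyl, compound 3 also falls within the scatter of compound 1, which carries the same 4-chlorophenyl group. Nothing available here explains why this single change moves the number.

The compounds shown leave open how a fluoro, bromo, methoxy or trifluoromethyl group would read at this position. They also leave open whether the same change would give a step of similar size on the core of compound 1.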